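Aniline swap on the shared core: compound 3 to compound 4

The compounds below may be only part of what the source reports. "The series", "measured", "known", "first", "only" and "open" are said of these compounds alone.

Compound 1 `O=C(CSc1nc(Nc2ccccc2)c2ccccc2n1)Nc1cccc(F)c1`, compound 2 `O=C(CSc1nc(Nc2ccccc2)c2ccccc2n1)Nc1ccc(Cl)cc1Cl` and compound 3 `C=CC(=O)Nc1cccc(NC(=O)CSc2nc(Nc3ccccc3F)c3ccccc3n2)c1` share one core and were tested in a functional assay on MDA-MB-231 cells (Homo sapiens) for inhibition, read by MTT assay, with a stated time of 72 h; on this read-out higher numbers stand for weaker inhibition and lower numbers for stronger inhibition. Compound 1 sits at the limit of > 50000 nM in this assay, at which 1 of the 3 values shown sits, a limit rather than a number, > 50000 nM. Compound 2 gives 19400 nM. Compound 3 gives 18700 nM, which lies within the scatter of compound 2. For the measured compounds named here, the single measured step, an at least 2.5-fold lower number from compound 1 to compound 2 (0.41 log units; beyond the scatter), concerns an amide-type nitrogen and begins from a limit, so it tells little about the position changed next. Compound 4 `C=CC(=O)Nc1cccc(NC(=O)CSc2nc(Nc3ccc(C(F)(F)F)cc3)c3ccccc3n2)c1` differs from compound 3 by 4-(trifluoromethyl)phenyl in place of 2-fluorophenyl on a nitrogen on an aromatic ring. Going by the values given here, no measured step touches this nitrogen on an aromatic ring, so a step no larger than the scatter is expected, a 1.2-fold lower number from compound 3 to compound 4 (0.07 log units; within the scatter). Compound 4 is therefore estimated at 16000 nM, with a range from 5000 nM to 50000 nM.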

Compound 4, half-maximal inhibitory concentration: 11500 nM
Compound 4: middle estimate off by 1.4-fold (0.14 log units), on the high side; low and high end bracket the measured number.
By their numbers in this assay, from the lowest: compounds 4, 3 and 2 (each within the scatter of the next). At a limit, above all of these: compound 1.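

Compound 3 and compound 4 lie within the scatter of each other in this assay (a 1.6-fold lower number from compound 3 to compound 4 (0.21 log units; within the scatter)). For the compounds shown here, this gives the first reading at the nitrogen on an aromatic ring: 4-(trifluoromethyl)phenyl in place of 2-fluorophenyl gives no step beyond the scatter. Nothing shown gives a cause for this step.

Open, as far as these compounds go, is whether a non-aromatic group on this nitrogen, such as a longer alkyl chain or one ending in a carboxylic acid or an amine, would give a step beyond the scatter. Also open, from the compounds shown here alone, is whether this position behaves the same with other groups on the amide-type nitrogen.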